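From isopropyl to cyclopropyl on the amine nitrogen

A few compounds are considered here, and "the series" means these few. Any claim that something is new, unique, unknown or untested is made for them only; others in the source may bear on it.

In a functional assay on HCT-15 cells (Homo sapiens) for inhibition, read by MTT assay, with a stated time of 72 h (a higher number here means a weaker inhibitor, a lower number a stronger inhibitor), the measured compounds read as follows:
Compound 1 `COc1ccc(CNCc2c(OC)cc(Oc3cccc(Nc4ccccc4)c3)cc2OC)cc1` gives 2650 nM
Compound 2 `CNCc1c(OC)cc(Oc2cccc(Nc3ccccc3)c2)cc1OC` gives 8930 nM
Compound 3 `COc1cc(Oc2cccc(Nc3ccccc3)c2)cc(OC)c1CNC(C)C` gives > 20000 nM

For compound 3 the assay returns only a limit of > 20000 nM and no number. In this assay compound 3 is the weakest of the three, with an at least 7.5-fold higher number from compound 1 to compound 3 (0.87 log units; beyond the scatter) and an at least 2.2-fold higher number from compound 2 to compound 3 (0.35 log units; beyond the scatter) on record.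

Going by the values given here, compound 4 `COc1cc(Oc2cccc(Nc3ccccc3)c2)cc(OC)c1CNC1CC1` carries cyclopropyl in place of isopropyl on an amine nitrogen and no measured step makes this exchange. The closest evidence comes from changes at the same nitrogen. The step for isopropyl in place of methyl is an at least 2.2-fold higher number from compound 2 to compound 3 (0.35 log units; beyond the scatter) and the step for hydrogen in place of 4-methoxyphenyl on a saturated chain carbon bound to an amine nitrogen is a 3.4-fold higher number from compound 1 to compound 2 (0.53 log units; beyond the scatter) in the same series. Both are modest, and the exchange in compound 4 is expected to be no larger than these. Going by these compounds, the true number of compound 3 remains unknown, which leaves the size of any change loosely defined. The estimated step is an at least 1.3-fold lower number from compound 3 to compound 4 (0.12 log units; that floor lies within the scatter) and is expected to be small, toward a lower number. Compound 4 is expected at 15000 nM with an estimated range from 7000 nM to 30000 nM and it may also return only a limit.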

Compound 4, half-maximal inhibitory concentration: 6140 nM
The estimate for compound 4 lay 2.4-fold (0.39 log units) above the measured number; the whole stated range lies above it.
By their numbers in this assay, from the lowest: compound 1; then compounds 4 and 2 (each within the scatter of the next). At a limit, above all of these: compound 3.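

In this assay, the amine nitrogen responds to more than the number of carbons it carries: isopropyl and cyclopropyl have the same count of heavy atoms and differ by one three-membered ring, yet the exchange gives an at least 3.2-fold lower number from compound 3 to compound 4 (0.51 log units; beyond the scatter). The earlier compounds shown here could suggest that a group larger than methyl costs activity at this nitrogen, but cyclopropyl shows no such cost, with a 1.5-fold lower number from compound 2 to compound 4 (0.16 log units; within the scatter), so only compound 3 carries that loss, while 4-methoxybenzyl remains the best group here, with a 2.3-fold higher number from compound 1 to compound 4 (0.36 log units; beyond the scatter). The step out of compound 3 is a floor and not a measured size, since compound 3 stands only at a limit: the limit of > 20000 nM in this assay, at which 1 of the 4 values shown sits.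

What the compounds shown leave open is whether the cyclopropyl result extends to larger rings such as cyclobutyl or cyclopentyl, or belongs to the three-membered ring alone. They also leave open whether the edge of 4-methoxybenzyl comes from the benzyl group itself or from its methoxy, a question that an unsubstituted benzyl on the same nitrogen would address.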